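Bromo on the core phenyl: compound 4 from compound 3

A few compounds are considered here, and "the series" means these few. Any claim that something is new, unique, unknown or untested is made for them only; others in the source may bear on it.

Measured so far in a functional assay on B16-F10 cells (Mus musculus) for inhibition, read by MTT assay, with a stated time of 72 h; on this read-out lower numbers stand for stronger inhibition and higher numbers for weaker inhibition:
compound 1 `N#Cc1c(Nc2ccc(Cl)cc2)nc(SCc2cn(Cc3ccccc3Cl)nn2)nc1-c1ccccc1` gives 1590 nM
compound 2 `N#Cc1c(Nc2cccc([N+](=O)[O-])c2)nc(SCc2cn(Cc3ccccc3Cl)nn2)nc1-c1ccccc1` gives 17200 nM
compound 3 `Cc1ccc(Nc2nc(SCc3cn(Cc4ccccc4Cl)nn3)nc(-c3ccccc3)c2C#N)cc1` gives 3390 nM

Compound 3 holds the second highest of the three numbers in this assay; the nearest measured neighbour is reached by a 2.1-fold higher number from compound 1 to compound 3 (0.33 log units; beyond the scatter), the furthest by a 5.1-fold lower number from compound 2 to compound 3 (0.71 log units; beyond the scatter).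

Compound 4 `Cc1ccc(Nc2nc(SCc3cn(Cc4ccccc4Cl)nn3)nc(-c3ccc(Br)cc3)c2C#N)cc1` differs from compound 3 by bromo in place of hydrogen on an aromatic carbon. Every measured step, namely an 11-fold higher number from compound 1 to compound 2 (1.03 log units; beyond the scatter), a 2.1-fold higher number from compound 1 to compound 3 (0.33 log units; beyond the scatter) and a 5.1-fold lower number from compound 2 to compound 3 (0.71 log units; beyond the scatter), alters the aryl group on the nitrogen, not the phenyl on the core, so none bears on this change. Among the measured compounds shown here, with no precedent, the expected step is a 1.0-fold higher number from compound 3 to compound 4 (0.00 log units; within the scatter), that is, none beyond the scatter in either direction. Compound 4 is therefore estimated at 3400 nM in this assay, expected to lie between 1200 nM and 9500 nM.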

Compound 4, half-maximal inhibitory concentration: 2870 nM
Compound 4: middle estimate off by 1.2-fold (0.07 log units), on the high side; low and high end bracket the measured number.
By their numbers in this assay, from the lowest: compounds 1, 4 and 3 (each within the scatter of the next, the first and the last beyond it); then compound 2.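

In this assay, among the compounds shown here, the change from phenyl to 4-bromophenyl on the core gives a 1.2-fold lower number from compound 3 to compound 4 (0.07 log units; within the scatter) and is the only step so far away from the aryl group on the nitrogen. Unlike the steps at that aryl group, this one stays within the scatter, so this position accepts bromo with no readable change in the number. No available data explain this result.

From the compounds shown here alone, whether an amine or a carboxylic acid at this place would leave the number equally unchanged remains open. Also open, going by these compounds, is whether bromo would give the same result alongside the 4-chlorophenyl group on the nitrogen.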